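The compounds below may be only part of what the source reports. "The series", "measured", "known", "first", "only" and "open" are said of these compounds alone.

Compound 1 `CCc1[nH]c2ccc(OC)cc2c1/C=C/C(=O)c1ccncc1` — 3200 nM
Compound 2 `CCCc1[nH]c2ccc(OC)cc2c1/C=C/C(=O)c1ccncc1` — 15300 nM
Compound 3 `COc1ccc2[nH]c(C(C)C)c(/C=C/C(=O)c3ccncc3)c2c1` — > 20000 nM

In a functional assay on U-251 cells (Homo sapiens) for inhibition, with stated times of 24 h and 48 h (a higher number here means a weaker inhibitor of growth, a lower number a stronger inhibitor of growth), compound 1 gives 3200 nM and compound 2 gives 15300 nM. For compound 3 the assay reports only a limit, > 20000 nM. Compound 3 therefore sits at the limit of > 20000 nM in this assay, at which 1 of the 3 values shown sits, the weakest position among the numbers shown, and its step from compound 1 is beyond the scatter. Compound 4 `COc1ccc2[nH]c(CC(C)C)c(/C=C/C(=O)c3ccncc3)c2c1` differs from compound 3 by isobutyl in place of isopropyl on an aromatic carbon. Among the measured compounds shown here, two measured steps bear on growing the chain at this position: a 4.8-fold higher number from compound 1 to compound 2 (0.68 log units; beyond the scatter) and an at least 6.2-fold higher number from compound 1 to compound 3 (0.79 log units; beyond the scatter), both toward weaker growth inhibition, while an at least 1.3-fold higher number from compound 2 to compound 3 (0.11 log units; that floor lies within the scatter) gives only a floor that lies within the scatter. The longer isobutyl chain is thus expected to keep compound 4 at or beyond the limit rather than restore potency. Compound 4 is expected to give 30000 nM, within a range from 15000 nM to 80000 nM. The step that the limit leaves unreadable from compound 3 to compound 4 that this estimate implies is expected to be no more than a small one toward weaker inhibition.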

Compound 4, concentration for 50% growth inhibition: 16600 nM
The estimate for compound 4 lay 1.8-fold (0.26 log units) above the measured number; low and high end bracket the measured number.
By their numbers in this assay, from the lowest: compound 1; then compounds 2 and 4 (each within the scatter of the next). At a limit, above all of these: compound 3.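

In this assay, the further methyl that turns propyl into isobutyl gives a 1.1-fold higher number from compound 2 to compound 4 (0.04 log units; within the scatter), while the larger change in the chain gives a 5.2-fold higher number from compound 1 to compound 4 (0.71 log units; beyond the scatter), toward weaker growth inhibition. In this assay compound 3 has only a limit, > 20000 nM. Isobutyl in place of isopropyl gives an at least 1.2-fold lower number from compound 3 to compound 4 (0.08 log units; that floor lies within the scatter), and this is only a floor set by that limit. Adding a methyl to the chain at this position therefore has no single size of effect: the same change on two cores in this assay, an at least 6.2-fold higher number (0.79 log units; beyond the scatter) from compound 1 to compound 3 and a 1.1-fold higher number (0.04 log units; within the scatter) from compound 2 to compound 4, at least 5.7-fold (0.76 log units) apart, beyond the scatter of two such steps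

The compounds shown leave open whether a methyl group, a bare hydrogen, or a chain ending in an amine at this position would match or improve on compound 1. They also leave unsettled how isopropyl truly compares with isobutyl.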